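The source may report more compounds than this note shows. Statements on the series, on what has been measured and on what is new or still open speak of the compounds shown alone.

Working notes on the succinimide-propanoyl piperazine series.

Compound 2 `CC(C(=O)N1CCN(c2ccccc2)CC1)N1C(=O)CCC1=O` is the anchor of this comparison. In a functional assay on the whole organism (strain Swiss) with Mus musculus as the target, in the maximal electroshock model, with a stated time of 2 h, at a dose of 300 mg/kg by the intraperitoneal route (a higher number here means a stronger effect of the compound at the dose given, a lower number a weaker effect), compound 2 gives 0%. It stands level with compound 1 `COc1cccc(N2CCN(C(=O)C(C)N3C(=O)CCC3=O)CC2)c1`, which in this assay gives 0%, and with compound 3 `CC(C(=O)N1CCN(c2ccc(C(F)(F)F)cc2)CC1)N1C(=O)CCC1=O`, which in this assay gives 0%. The step of no change at the digits printed from compound 1 to compound 2 (within the scatter) and the step of no change at the digits printed from compound 2 to compound 3 (within the scatter) are both within the scatter: neither removing the methoxy nor adding a trifluoromethyl moved the read-out.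

Compound 4 `CC(C(=O)N1CCN(c2ccccc2C(F)(F)F)CC1)N1C(=O)CCC1=O` differs from compound 2 by trifluoromethyl in place of hydrogen on an aromatic carbon. The bearing step is no change at the digits printed from compound 2 to compound 3 (within the scatter), where the same group entered on an aromatic carbon of the same ring, at a different place, and brought no change beyond the scatter. With all three measured compounds at the same level and no step beyond the scatter anywhere in the set, no change beyond the scatter is expected here either, no change at the digits printed from compound 2 to compound 4 (within the scatter). Compound 4 is therefore estimated to give 0% in this assay, with a range from 0% to 10%.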

Compound 4, a percentage reported as activity, at one dose (the size of the read-out at that dose, not a potency): 75%
The estimate for compound 4 lay 75 percentage points below the measured number; the whole stated range lies below it.
By their numbers in this assay, from the lowest: compounds 1, 2 and 3 (each within the scatter of the next); then compound 4.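

Placed on an aromatic carbon ortho to a large group, trifluoromethyl in place of hydrogen brings a number 75 percentage points higher from compound 2 to compound 4 (beyond the scatter) in this assay and so separates this position from everything seen before. The identical group on the same ring does not behave the same way at both places: compound 3 gives 0% with it at a different place and compound 4 gives 75% with it ortho to a large group, so in these two compounds the place of the group matters as well as its presence. No measurement shown here accounts for this difference.

From the compounds shown here alone, whether the response belongs to trifluoromethyl itself or would also appear with chlorine or a nitrile at this place remains open. With a single dose and time shown, the potency of compound 4 also remains open.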